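This account rests on a few compounds, and the source may have more. Where it says the series, first, only, none or still open, it means among the compounds named here.

Working notes on the malonamide ester series in an assay on microsomes from intestine for inhibition of acyl-CoA:cholesterol acyltransferase (Oryctolagus cuniculus); a higher number here means a weaker inhibitor, a lower number a stronger inhibitor.

Compound 1 `CCCCC(C)(C)OC(=O)CC(=O)Nc1c(C(C)C)cccc1C(C)C` gives 15 nM. Compound 2 `CCCCCCCCCCCCC(C)(C)OC(=O)CC(=O)Nc1c(C(C)C)cccc1C(C)C` gives 12 nM; it differs from compound 1 by octyl in place of hydrogen on a saturated chain carbon, five bonds along the chain from an oxygen next to a carbonyl group, and this change made a 1.3-fold lower number from compound 1 to compound 2 (0.10 log units; within the scatter). Compound 3 `CCCCCCCCOC(=O)CC(=O)Nc1c(C(C)C)cccc1C(C)C` gives 260 nM, the highest number of the three measured; its core differs from that of compound 1 by octyl in place of 1,1-dimethylpentyl on an oxygen next to a carbonyl group, a change that made a 17-fold higher number from compound 1 to compound 3 (1.24 log units; beyond the scatter).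

Compound 4 `CCCCCCCCCCCCCCCCOC(=O)CC(=O)Nc1c(C(C)C)cccc1C(C)C` is not yet measured. It differs from compound 3 by octyl in place of hydrogen on a saturated chain carbon, eight bonds along the chain from an oxygen next to a carbonyl group. This is the same kind of change as that from compound 1 to compound 2, not the same one: there the octyl enters five bonds along the chain from an oxygen next to a carbonyl group, here eight bonds along the chain from an oxygen next to a carbonyl group.

In this assay the step from compound 3 to compound 4 is expected to be small, a 1.3-fold lower number from compound 3 to compound 4 (0.11 log units; within the scatter), because the comparable chain extension on the other core gave a 1.3-fold lower number from compound 1 to compound 2 (0.10 log units; within the scatter), within the scatter. Compound 4 is therefore estimated at 200 nM, expected to lie between 80 nM and 500 nM.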

Compound 4, half-maximal inhibitory concentration: 35 nM
Estimate against measurement, compound 4: 5.7-fold (0.76 log units) above; the whole stated range lies above it.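

In this assay the octyl change on the core of compound 3 gives a 7.4-fold lower number from compound 3 to compound 4 (0.87 log units; beyond the scatter), so on this core the longer chain lowers the number by more than the scatter. For the compounds shown here, this does not show why the two cores respond differently: only two pairs are at hand, and they differ in the place of the octyl as well as in the core, five bonds along the chain from the oxygen in one pair and eight bonds along the chain in the other, so core and place cannot be separated. What can be said is that the size of this change cannot be carried from one core to the other in this series, since the two steps differ: the same change on two cores in this assay, a 1.3-fold lower number (0.10 log units; within the scatter) from compound 1 to compound 2 and a 7.4-fold lower number (0.87 log units; beyond the scatter) from compound 3 to compound 4, 5.9-fold (0.77 log units) apart, beyond the scatter of two such steps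

Still open, as far as these compounds go, is whether a longer chain on the ester oxygen would lower the number further on either core. Also open, from the compounds shown here alone, is how a chain carrying an amine or a carboxylic acid would behave.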